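A Methylphenyl-Thiazolyl Analogue of Compound 1: Expected Potency

A few compounds are considered here, and "the series" means these few. Any claim that something is new, unique, unknown or untested is made for them only; others in the source may bear on it.

Compound 1 `NC(=S)N1N=C(c2ccc(N3CCCCC3)cc2)CC1c1ccc(Cl)cc1`: 22300 nM
Compound 2 `Clc1ccc(C2CC(c3ccc(N4CCCCC4)cc3)=NN2c2nc(-c3ccc(Br)cc3)cs2)cc1`: > 100000 nM (a limit)
Compound 3 `FC(F)(F)c1ccc(-c2csc(N3N=C(c4ccc(N5CCCCC5)cc4)CC3c3ccc(Cl)cc3)n2)cc1`: 23700 nM

In a functional assay on MCF7 cells (Homo sapiens) for antiproliferative activity, read by MTT assay, with a stated time of 72 h (a higher number here means a weaker inhibitor, a lower number a stronger inhibitor), compound 1 gives 22300 nM, the lowest of the two numbers shown, and compound 3 sits within the scatter of it with 23700 nM. For compound 2 this assay reports only a limit, > 100000 nM (the limit of > 100000 nM in this assay, at which 1 of the 3 values shown sits). Compound 4 `Cc1ccc(-c2csc(N3N=C(c4ccc(N5CCCCC5)cc4)CC3c3ccc(Cl)cc3)n2)cc1` differs from compound 1 by a group of 12 heavy atoms (10 carbon, 1 nitrogen, 1 sulfur; one five-membered aromatic ring with 2 hetero atoms, one six-membered aromatic ring of carbon only) in place of a group of 3 heavy atoms (1 carbon, 1 nitrogen, 1 sulfur; no ring), on an amine nitrogen in a ring. The same kind of exchange, carrying bromo rather than methyl, gave an at least 4.4-fold higher number from compound 1 to compound 2 (0.65 log units; beyond the scatter), whereas an at least 4.2-fold lower number from compound 2 to compound 3 (0.62 log units; beyond the scatter) returned the number to the level of compound 1. The methylphenyl variant is therefore expected to fall between these outcomes, with a step of a 1.8-fold higher number from compound 1 to compound 4 (0.25 log units; within the scatter). Compound 4 is estimated at 40000 nM, in a range from 15000 nM to 150000 nM.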

Compound 4, half-maximal inhibitory concentration: > 100000 nM
Compound 4 gave a limit, no number; the forecaster's own chance of this, stated with the estimate: 30%; middle value at least 2.5-fold (0.39 log units) away from the limit.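

In this assay compound 4 gives only a limit, and compound 2 sits at the same limit: the limit of > 100000 nM in this assay, at which 2 of the 4 values shown sit. The 4-(4-methylphenyl)-1,3-thiazol-2-yl group on the amine nitrogen in a ring thus gives an at least 4.4-fold higher number from compound 1 to compound 4 (0.65 log units; beyond the scatter), while methyl in place of trifluoromethyl gives an at least 4.2-fold higher number from compound 3 to compound 4 (0.62 log units; beyond the scatter). Of the three groups shown on that aromatic carbon, only trifluoromethyl stays within the scatter of compound 1, and the step between compound 2 and compound 4 cannot be read from two limits.

Going by these compounds, whether a methoxy group or a nitrile on that aromatic carbon would behave like trifluoromethyl or like methyl remains open. On these data alone, how far compound 2 and compound 4 lie beyond the limit also remains open.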